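Ethoxy in place of methoxymethoxy on a flavanone ether

The source may hold more compounds than are shown below. What is called first, only, known or untested is meant among the compounds shown, and "the series" means these compounds.

Measured so far:
compound 1 `CC(C)c1ccc(COc2ccccc2C2CC(=O)c3ccccc3O2)cc1`, 91.5%
compound 2 `COCOc1ccccc1C1CC(=O)c2ccccc2O1`, 35.2%

In a functional assay on RAW264.7 cells (Mus musculus) for inhibition, read by immunoassay, with a stated time of 12 h, tested at 30 uM (on this read-out higher numbers stand for more inhibition at the one concentration tested (going by the name of the read-out) and lower numbers for less inhibition), compound 1 gives 91.5%. Compound 2 stands lowest of the two numbers in this assay, with 35.2%. Among the measured compounds shown here, the one measured step, a number 56.3 percentage points lower from compound 1 to compound 2 (beyond the scatter), shows how strongly the group on the saturated chain carbon bound to an oxygen on the aromatic ring sways this assay.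

Compound 3 `CCOc1ccccc1C1CC(=O)c2ccccc2O1` is not yet measured. The change is methyl in place of methoxy on a saturated chain carbon bound to an oxygen on an aromatic ring. For the measured compounds named here, no measured step trades methoxy for methyl at this place; the only guide is that compound 1 with its much larger group gave 91.5%, while compound 2 gave 35.2%. Since methyl and methoxy are both small groups, a step no larger than the scatter is expected here, in either direction. The estimated step of a number 2.8 percentage points higher from compound 2 to compound 3 (within the scatter) puts compound 3 at an expected 38%, within 15% to 65%.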

Compound 3, a percentage reported as inhibition, at one concentration (the size of the read-out at that concentration, not a potency): 29.6%
Estimate against measurement, compound 3: 8.4 percentage points above; low and high end bracket the measured number.
By their numbers in this assay, from the lowest: compounds 3 and 2 (each within the scatter of the next); then compound 1.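

In this assay, methyl in place of methoxy gives a number 5.6 percentage points lower from compound 2 to compound 3 (within the scatter), so on the saturated chain carbon bound to an oxygen on an aromatic ring, this read-out does not tell these two groups apart. Methyl in place of 4-isopropylphenyl gives a number 61.9 percentage points lower from compound 1 to compound 3 (beyond the scatter), so the large gap to compound 1 now appears with two different replacements rather than one. Nothing measured here explains these numbers.

The compounds shown leave open what lies between these groups and 4-isopropylphenyl. A plain phenyl, a longer chain or an amine at this place could land near compound 1 or near compound 2 and compound 3, and only such groups would show which part of 4-isopropylphenyl goes with the high number.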